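Changing the ring on the piperazine of a chromanamide

The compounds below may be only part of what the source reports. "The series", "measured", "known", "first", "only" and "open" are said of these compounds alone.

Among the compounds with values here, compound 1 `CCNc1cccnc1N1CCN(C(=O)C2(C)CCc3c(C)c(O)c(C)c(C)c3O2)CC1` gives 12000 nM in a functional assay (brain) for inhibition, with Rattus norvegicus as the target (on this read-out lower numbers stand for stronger inhibition and higher numbers for weaker inhibition), the highest of the two numbers known here; compound 2 `CCN(CC)c1ccc(N2CCN(C(=O)C3(C)CCc4c(C)c(O)c(C)c(C)c4O3)CC2)nc1N(CC)CC` gives 200 nM in this assay. Compound 3 `COc1ccccc1N1CCN(C(=O)C2(C)CCc3c(C)c(O)c(C)c(C)c3O2)CC1` is not yet measured. It differs from compound 1 by one change: 2-methoxyphenyl in place of 3-(ethylamino)pyridin-2-yl on an amine nitrogen in a ring. Within the data shown here, no step between measured compounds is recorded for this change, so the account can only expect; since compound 2 reaches 200 nM, a step toward lower numbers, beyond the scatter, is expected for compound 3, as a 4.8-fold lower number from compound 1 to compound 3 (0.68 log units; beyond the scatter). Compound 3 is therefore estimated at 2500 nM in this assay, within a range from 400 nM to 12000 nM.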

Compound 3, half-maximal inhibitory concentration: 15000 nM
Beside the measured number, compound 3's estimate is 6.0-fold (0.78 log units) below it; the whole stated range lies below it.
By their numbers in this assay, from the lowest: compound 2; then compounds 1 and 3 (each within the scatter of the next).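

Placing 2-methoxyphenyl in place of 3-(ethylamino)pyridin-2-yl on an amine nitrogen in a ring gives, in this assay, a 1.3-fold higher number from compound 1 to compound 3 (0.10 log units; within the scatter). The entering group has no hydrogen-bond donor and a ring of carbon only, and still the two compounds cannot be told apart at this position. Nothing measured here accounts for this result. As far as these compounds go, it remains open whether a simple unsubstituted phenyl or a phenyl bearing a carboxylic acid at this place would take the number beyond the scatter of these two compounds.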